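Replacing Chloro with Trifluoromethyl: an Expected Cytotoxicity Shift

The source may hold more compounds than are shown below. What is called first, only, known or untested is meant among the compounds shown, and "the series" means these compounds.

Compound 1 `NCC1CCN(c2c(F)cc3c(=O)c(C(=O)O)cn(C4CC4)c3c2Cl)C1` carries a chloro group on the shared core. In a functional assay on V79 cells (Cricetulus griseus) for cytotoxicity, read by colony formation (on this read-out higher numbers stand for weaker inhibition and lower numbers for stronger inhibition), compound 1 gives 8 ug/mL. Compound 2 `NCC1CCN(c2c(F)cc3c(=O)c(C(=O)O)cn(C4CC4)c3c2C(F)(F)F)C1` differs from it by trifluoromethyl in place of chloro on an aromatic carbon, and in this assay compound 2 gives 38 ug/mL, which amounts to a 4.8-fold higher number from compound 1 to compound 2 (0.68 log units; beyond the scatter). Compound 3 `NC1CCN(c2c(F)cc3c(=O)c(C(=O)O)cn(C4CC4)c3c2Cl)CC1` differs from compound 1 by 4-aminopiperidin-1-yl in place of 3-(aminomethyl)pyrrolidin-1-yl on an aromatic carbon; in this assay compound 3 gives 18 ug/mL, the result being a 2.3-fold higher number from compound 1 to compound 3 (0.35 log units; beyond the scatter).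

Compound 4 `NC1CCN(c2c(F)cc3c(=O)c(C(=O)O)cn(C4CC4)c3c2C(F)(F)F)CC1` has not yet been measured. It differs from compound 3 by trifluoromethyl in place of chloro on an aromatic carbon. This is the same kind of change as that made from compound 1 to compound 2, though here the place is ortho to a 4-aminopiperidin-1-yl group, where before it was ortho to a 3-(aminomethyl)pyrrolidin-1-yl group. Because the earlier change produced a 4.8-fold higher number from compound 1 to compound 2 (0.68 log units; beyond the scatter), a step of roughly the same size is expected in this assay, namely a 3.9-fold higher number from compound 3 to compound 4 (0.59 log units; beyond the scatter). Compound 4 is therefore estimated at 70 ug/mL in this assay, with a likely range from 30 ug/mL to 160 ug/mL.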

Compound 4, half-maximal inhibitory concentration: 20 ug/mL
The estimate for compound 4 lay 3.5-fold (0.54 log units) above the measured number, and the stated range ends above it.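

In this assay, trifluoromethyl in place of chloro gives a 1.1-fold higher number from compound 3 to compound 4 (0.05 log units; within the scatter) when the group ortho to it is 4-aminopiperidin-1-yl, so the step seen with 3-(aminomethyl)pyrrolidin-1-yl did not carry over to this core: the same change on two cores in this assay, a 4.8-fold higher number (0.68 log units; beyond the scatter) from compound 1 to compound 2 and a 1.1-fold higher number (0.05 log units; within the scatter) from compound 3 to compound 4, 4.3-fold (0.63 log units) apart, beyond the scatter of two such steps. Read the other way, 4-aminopiperidin-1-yl in place of 3-(aminomethyl)pyrrolidin-1-yl gives a 1.9-fold lower number from compound 2 to compound 4 (0.28 log units; within the scatter) on the trifluoromethyl core, which does not match the step on the chloro core: the same change on two cores in this assay, a 2.3-fold higher number (0.35 log units; beyond the scatter) from compound 1 to compound 3 and a 1.9-fold lower number (0.28 log units; within the scatter) from compound 2 to compound 4, 4.3-fold (0.63 log units) apart, beyond the scatter of two such steps. Among these compounds, then, the size of each step depends on the group at the other place, but this rests on a single set of compounds in one assay and does not show why the steps differ or whether the same holds for other pairs of groups.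

The compounds shown leave open how a bromo or methoxy group at the same place would behave with either amine. They also leave open how a piperazin-1-yl group would pair with chloro and trifluoromethyl.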